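Chloro to Cyano on a Shared Pyrimidine-Free Core

This account rests on a few compounds, and the source may have more. Where it says the series, first, only, none or still open, it means among the compounds named here.

Measured compounds:
compound 1, `O=C(Nc1cc(C(F)(F)F)cc(C(F)(F)F)c1)c1cnc(C(F)(F)F)nc1C(F)(F)F`: > 10000 nM (a limit of the assay)
compound 2, `O=C(Nc1cc(C(F)(F)F)cc(C(F)(F)F)c1)c1cnc(Cl)nc1C(F)(F)F`: 50 nM

Two compounds share a core and differ at one aromatic carbon. In an assay on Jurkat cells for activation of nuclear factor NF-kappa-B complex (Homo sapiens) (on this read-out higher numbers stand for weaker inhibition and lower numbers for stronger inhibition), compound 1 gives > 10000 nM, which is a limit of the assay and not a number. In this assay compound 2 gives 50 nM. Among the compounds with values here, the single measured step, an at least 200-fold lower number from compound 1 to compound 2 (2.30 log units; beyond the scatter), is large and beyond the scatter. Among the values shown, compound 2 holds the only number; the other value is a limit (the limit of > 10000 nM in this assay, at which 1 of the 2 values shown sits).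

Compound 3, `N#Cc1ncc(C(=O)Nc2cc(C(F)(F)F)cc(C(F)(F)F)c2)c(C(F)(F)F)n1`, has not been measured in this assay. It differs from compound 2 by cyano in place of chloro on an aromatic carbon. Within the data shown here, no measured step exchanges chloro for cyano; the one measured step replaced trifluoromethyl with chloro and brought a large gain, and it bears on compound 3 only indirectly, as both chloro and cyano are far from trifluoromethyl in what they carry. A small to moderate step is therefore expected, with weaker inhibition slightly more likely than stronger.

For compound 3 the expected value in this assay is 150 nM, with a range from 30 nM to 1500 nM. The expected step, a 3.0-fold higher number from compound 2 to compound 3 (0.48 log units; beyond the scatter), is estimated to stay well inside the size of the measured step.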

Compound 3, half-maximal inhibitory concentration: > 10000 nM
Compound 3 gave a limit, no number; the forecaster's own chance of this, stated with the estimate: 10%; middle value at least 66-fold (1.82 log units) from the limit.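

At the aromatic carbon between two ring nitrogen atoms, cyano in place of chloro gives an at least 200-fold higher number from compound 2 to compound 3 (2.30 log units; beyond the scatter) in this assay, so this single exchange can carry a change as large as any shown for the series. Within the data shown here, the earlier step, an at least 200-fold lower number from compound 1 to compound 2 (2.30 log units; beyond the scatter), showed only that chloro was far better than trifluoromethyl at this carbon; with cyano also failing to give a number, chloro is the only one of the three groups here that does, and the activity of compound 2 does not carry over to every replacement of trifluoromethyl. Compound 1 and compound 3 both stand at a limit of the assay and not at a number, so the step from one to the other cannot be read, and neither group can be ranked against the other: the limit of > 10000 nM in this assay, at which 2 of the 3 values shown sit.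

The three compounds leave open whether any group other than chloro at this carbon, such as bromo, an amine or a methoxy group, would give a number in this assay. They also leave open how far compound 1 and compound 3 lie beyond that limit.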